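Tert-butyl for methyl on the thioether-linked phenyl of compound 1

The compounds below may be only part of what the source reports. "The series", "measured", "known", "first", "only" and "open" are said of these compounds alone.

For the measured compounds named here, compound 1 `Cc1ccc(SCc2ccc(/C=C/C(=O)Nc3ccccc3N)cc2)cc1` is one of three compounds measured in a functional assay on SMMC-7721 cells (Homo sapiens) for inhibition, read by CCK-8 assay, with a stated time of 72 h, tested at 8 uM (on this read-out lower numbers stand for less inhibition of growth and higher numbers for more inhibition of growth at the one concentration tested), where compound 1 gives 22.2%. Compound 2 `Nc1ccccc1NC(=O)c1ccc(CSc2ccc(Br)cc2)cc1` gives 25.3% in this assay, a number within the scatter of the value of compound 1. Compound 3 `Nc1ccccc1NC(=O)c1ccc(CSc2ccc(C(F)(F)F)cn2)cc1` gives 7.57%, which lies beyond the scatter below compound 1, so compound 1 stands second highest of the three. Compound 4 `CC(C)(C)c1ccc(SCc2ccc(/C=C/C(=O)Nc3ccccc3N)cc2)cc1` differs from compound 1 in one place (tert-butyl in place of methyl on an aromatic carbon). Going by the values given here, no measured pair shows what this change does to growth inhibition. The account therefore expects the step from compound 1 to compound 4 a number 1.8 percentage points higher from compound 1 to compound 4 (within the scatter) to stay within the scatter, with no clear direction. Compound 4 is thus estimated to give 24% in this assay, with a range from 10% to 38%.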

Compound 4, percent growth inhibition at one concentration: 23.6%
Beside the measured number, compound 4's estimate is 0.4 percentage points above it; the measured number falls inside the stated range.
By their numbers in this assay, from the lowest: compound 3; then compounds 1, 4 and 2 (each within the scatter of the next).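

Tert-butyl in place of methyl on this aromatic carbon gives a number 1.4 percentage points higher from compound 1 to compound 4 (within the scatter) in this assay, so this position takes the change with no clear shift in growth inhibition at the one concentration tested. For the compounds shown here, this is the first pair to show this change directly, and it is a single pair on one core. No supporting measurement bears on this result. The compounds shown leave open whether an amine or a carboxylic acid in this place would also leave the number within the scatter of compound 1.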